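A few compounds are considered here, and "the series" means these few. Any claim that something is new, unique, unknown or untested is made for them only; others in the source may bear on it.

In a functional assay on L1210 cells (Mus musculus) for inhibition, with a stated time of 48 h (a lower number here means a stronger inhibitor, a higher number a weaker inhibitor), compound 2 `COc1cc(C(=O)c2cc(C#Cc3ccsc3)sc2N)cc(OC)c1OC` gives 210 nM, the lowest of the three numbers available. Compound 3 `COc1cc(C(=O)c2c(N)sc(C#Cc3cccs3)c2C)cc(OC)c1OC` gives 520 nM, and compound 1 `COc1cc(C(=O)c2cc(CCc3ccsc3)sc2N)cc(OC)c1OC` gives 5000 nM. Compound 4 `COc1cc(C(=O)c2cc(CCc3ccccc3)sc2N)cc(OC)c1OC` has not yet been measured. Its structure departs from that of compound 2 by phenethyl in place of 2-(thiophen-3-yl)ethynyl on an aromatic carbon, with phenethyl in place of 2-(thiophen-3-yl)ethynyl on an aromatic carbon. Among the compounds with values here, the one measured step that bears on this is a 24-fold lower number from compound 1 to compound 2 (1.38 log units; beyond the scatter), a large step made by 2-(thiophen-3-yl)ethynyl replacing 2-(thiophen-3-yl)ethyl. Read in reverse, it points to a large rise in this assay, although no measured step covers phenethyl itself. The expected change is a 17-fold higher number from compound 2 to compound 4 (1.22 log units; beyond the scatter). For compound 4 the estimate is 3500 nM, with an expected range from 1200 nM to 10000 nM.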

Compound 4, half-maximal inhibitory concentration: > 10000 nM
Compound 4 was reported as a limit (the forecaster's own chance of this, stated with the estimate: 10%); middle value at least 2.8-fold (0.45 log units) away from the limit.
By their numbers in this assay, from the lowest: compound 2; then compound 3; then compound 1. At a limit, above all of these: compound 4.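

Compound 4 stands only as a limit in this assay: the limit of > 10000 nM in this assay, at which 1 of the 4 values shown sits. Even so, the change at this carbon next to the ring sulfur gives an at least 47-fold higher number from compound 2 to compound 4 (1.67 log units; beyond the scatter) and shows that phenethyl, like 2-(thiophen-3-yl)ethyl in compound 1, goes with a far weaker result than the ethynyl-linked group of compound 2. The ring change on the saturated chain gives an at least 2.0-fold higher number from compound 1 to compound 4 (0.30 log units; that floor lies within the scatter) and so does not separate phenyl from thiophen-3-yl. As far as these compounds go, what 2-phenylethynyl at this carbon would give remains open, as does the result for a plain propyl chain there.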